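Side-chain change from compound 2 to compound 3

A few compounds are considered here, and "the series" means these few. Any claim that something is new, unique, unknown or untested is made for them only; others in the source may bear on it.

Measured in a functional assay (trachea) with Cavia porcellus as the target; a higher number here means a weaker inhibitor, a lower number a stronger inhibitor:
- compound 1 `O=c1c2ccccc2c(-c2cccnc2)nn1CC1CCCCC1`: 209 nM
- compound 2 `CC(=O)OCCn1nc(-c2cccnc2)c2ccccc2c1=O`: 9770 nM

Compound 2 holds the higher of the two numbers and is the weaker inhibitor, beyond the scatter. The next compound is compound 3 `O=c1c2ccccc2c(-c2cccnc2)nn1CCSc1nccs1`, with this change: (1,3-thiazol-2-yl)sulfanyl in place of acetoxy on a saturated chain carbon, two bonds along the chain from an aromatic nitrogen. In words, (1,3-thiazol-2-yl)sulfanyl replaces acetoxy on a saturated chain carbon, two bonds along the chain from an aromatic nitrogen.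

Among the measured compounds shown here, only one measured step bears on this: a 47-fold higher number from compound 1 to compound 2 (1.67 log units; beyond the scatter), which is large. There the loss of the cyclohexyl ring went with the higher number. The entering group also holds a ring, but a single pair cannot show that a ring matters. A moderate move to a lower number in this assay is expected, smaller than that measured step. The expected step is a 9.8-fold lower number from compound 2 to compound 3 (0.99 log units; beyond the scatter). The estimated value for compound 3 is 1000 nM, with an expected range of 200 nM to 5000 nM.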

Compound 3, half-maximal inhibitory concentration: 10500 nM
Compound 3: the middle estimate sits 11-fold (1.02 log units) below what was measured, and the stated range ends below it.
By their numbers in this assay, from the lowest: compound 1; then compounds 2 and 3 (each within the scatter of the next).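

In this assay, the step from acetoxy to (1,3-thiazol-2-yl)sulfanyl on this saturated chain carbon leaves the number unchanged within the scatter (a 1.1-fold higher number from compound 2 to compound 3 (0.03 log units; within the scatter)), although the entering group carries a five-membered aromatic ring and the leaving group has no ring. A ring in the side chain is therefore not enough to recover the lower number of compound 1, as the comparison with ((1,3-thiazol-2-yl)sulfanyl)methyl in place of cyclohexyl shows (a 50-fold higher number from compound 1 to compound 3 (1.70 log units; beyond the scatter)). No measurement at hand accounts for either result.

Still open, as far as these compounds go, is whether the lower number of compound 1 depends on the saturated cyclohexyl ring or on how that ring sits on the chain. A cyclohexylethyl chain, a phenyl ring, an amine or a carboxylic acid at this position could help separate these possibilities.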